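Aryl replacement on the shared core, compound 1 to compound 4

The compounds below may be only part of what the source reports. "The series", "measured", "known", "first", "only" and "open" are said of these compounds alone.

Compound 1 `CC(C)OC(=O)N1CCC(Oc2ncnc3c2CCN3c2ccc(S(C)(=O)=O)cc2)CC1` gives 154% in a functional assay on CHO-K1 cells with Glucose-dependent insulinotropic receptor (Homo sapiens) as the target, read by a luciferase reporter, with a stated time of 5 h (on this read-out higher numbers stand for larger maximal responses and lower numbers for smaller maximal responses), the highest of the three numbers to hand. Compound 2 `CC(C)COC(=O)N1CCC(Oc2ncnc3c2CCN3c2ccc(S(C)(=O)=O)cc2F)CC1` gives 94% and compound 3 `CS(=O)(=O)c1ccc(N2CCc3c(OC4CCN(C(=S)Sc5ccccc5)CC4)ncnc32)c(F)c1` gives 103%; both lie well below compound 1, by gaps beyond the scatter. Compound 1 and compound 2 differ in more than one place, so their values are only compared side by side.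

Compound 4 `CC(C)OC(=O)N1CCC(Oc2ncnc3c2CCN3c2ccc(C#N)cn2)CC1` carries 5-cyanopyridin-2-yl in place of 4-(methylsulfonyl)phenyl on a nitrogen on an aromatic ring in a ring. Among the measured compounds shown here, the one measured step, a number 9 percentage points higher from compound 2 to compound 3 (within the scatter), concerns a group on an amine nitrogen in a ring, not the ring attached to the nitrogen on the aromatic ring, and it lay within the scatter. For the measured compounds named here, no measured pair bears on the exchange made in compound 4, so the direction of its effect is open.

Without a guiding step, the working expectation for compound 4 is a value near that of compound 1 but with wide uncertainty, estimated at 130% with a range from 80% to 170%. This estimate corresponds to an expected step of a number 24 percentage points lower from compound 1 to compound 4 (beyond the scatter).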

Compound 4, largest response reached (reported as percent of maximum), in percent of the reference or control that the assay uses: 105%
The estimate for compound 4 lay 25 percentage points above the measured number, and the stated range covers the measured number.
By their numbers in this assay, from the lowest: compounds 2, 3 and 4 (each within the scatter of the next, the first and the last beyond it); then compound 1.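

Among the compounds shown here, the exchange of 4-(methylsulfonyl)phenyl for 5-cyanopyridin-2-yl on a nitrogen on an aromatic ring in a ring gives the first measured step at this position: in this assay, the result is a number 49 percentage points lower from compound 1 to compound 4 (beyond the scatter), a large change. For the compounds shown here, the maximal response therefore depends on the group at this position, whereas the only earlier step, a number 9 percentage points higher from compound 2 to compound 3 (within the scatter), was at an amine nitrogen in a ring and stayed within the scatter. No available evidence accounts for the size of the new step.

The exchange alters the ring's atoms and its substituent together, so the contribution of each remains unresolved. Open cases include a six-membered aromatic ring of carbon only bearing a nitrile, and a primary amide in place of the nitrile.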